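This account rests on a few compounds, and the source may have more. Where it says the series, first, only, none or still open, it means among the compounds named here.

Measured compounds and their values in this series:

Compound 1, `O=C(O)Cc1sc(C(c2ccc(F)cc2)c2ccc(F)cc2)nc1-c1ccnc(N2CCCC2)c1`, gives 80% in an in vitro functional assay on HEK285-7 cells for antagonist activity at prostaglandin D2 receptor 2 (Homo sapiens), read by BRET and beta-arrestin recruitment; on this read-out higher numbers stand for larger maximal responses and lower numbers for smaller maximal responses.
Compound 2, `NS(=O)(=O)c1ccc(-c2nc(C(c3ccc(F)cc3)c3ccc(F)cc3)sc2CC(=O)O)cc1`, gives 80% in this assay.
Compound 3, `O=C(O)Cc1sc(C(c2ccccc2)c2ccc(Cl)cc2)nc1-c1ccc(F)cc1`, gives 80% in this assay.

On these numbers compound 2 stands level with compound 1 and with compound 3; none of the three is set apart from the others beyond the scatter of repeated measurements. Going by the values given here, the only step between compounds that differ in one place is the one from compound 1 to compound 2, and in this assay it came out as no change at the digits printed from compound 1 to compound 2 (within the scatter).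

Compound 4, `CS(=O)(=O)Nc1cccc(-c2nc(C(c3ccc(F)cc3)c3ccc(F)cc3)sc2CC(=O)O)c1`, has not yet been measured. It differs from compound 2 in one place: 3-(methanesulfonamido)phenyl in place of 4-sulfamoylphenyl on an aromatic carbon.

Among the compounds with values here, the one measured step bears directly on this change, since it too replaced the group on the same aromatic carbon of the shared core, and it left the maximal response unchanged within the scatter. All three measured compounds, carrying three different groups at that position, give the same read-out at the digits shown. On that basis no step beyond the scatter is expected for compound 4 in this assay. The expected step is no change at the digits printed from compound 2 to compound 4 (within the scatter). Compound 4 is therefore estimated at 80%, with a range from 65% to 95%.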

Compound 4, largest response reached (reported as efficacy), in percent of the reference or control that the assay uses: 80%
Beside the measured number, compound 4's estimate shows no gap at the digits printed, within the range that was stated.
By their numbers in this assay, from the lowest: compounds 1, 2, 3 and 4 (each within the scatter of the next).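

In this assay, putting 3-(methanesulfonamido)phenyl on this aromatic carbon in place of 4-sulfamoylphenyl gave no change at the digits printed from compound 2 to compound 4 (within the scatter), so the earlier level holds for a group with one more heavy atom and the same counts of hydrogen-bond donors and acceptors. Set against the 2-(pyrrolidin-1-yl)pyridin-4-yl group, the same entering group gave no change at the digits printed from compound 1 to compound 4 (within the scatter). With the rest of the structure held the same, compounds 1, 2 and 4 now form a set of three different groups at this carbon that cannot be told apart by their maximal response in this assay, and no group among them goes against that sameness.

The compounds shown give no reason for this sameness. They also leave open whether the level would hold with a carboxylic acid or an amine on the phenyl ring, with a longer chain in place of the methyl of the methanesulfonamido group, or with a small group such as a lone fluorine at this carbon.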